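Opening the Ring in Compound 3

This account rests on a few compounds, and the source may have more. Where it says the series, first, only, none or still open, it means among the compounds named here.

Measured in a physicochemical assay for lipophilicity; a higher number here means a more lipophilic compound, a lower number a more polar compound:
- compound 1 `O=C(CN(C(=O)C1CCCCC1)C1CCCCC1)Nc1cc(F)cc(F)c1`: "not determined" (no result reported)
- compound 2 `O=C(CN(C(=O)c1ccc(N2CCCC2)cc1)C1CCCCC1)Nc1cc(F)cc(F)c1`: 4.5
- compound 3 `O=C(CN(C(=O)c1ccc(-c2ccccn2)cc1)C1CCCOC1)Nc1cc(F)cc(F)c1`: 2.7

Only two of these compounds have numbers to compare, since compound 1 has no reported result. Compound 3, at 2.7, holds the lower of the two numbers. Compound 2 stands higher at 4.5, and that gap lies beyond the usual scatter of repeated measurements.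

The next compound to be measured is compound 4 `CCC(COC)N(CC(=O)Nc1cc(F)cc(F)c1)C(=O)c1ccc(-c2ccccn2)cc1`. It keeps everything in compound 3 except for one group, with 1-(methoxymethyl)propyl in place of oxan-3-yl on an amide-type nitrogen. The group that leaves holds a six-membered non-aromatic ring, and the group that enters has no ring. The other counts match.

Among the measured compounds shown here, no two measured compounds differ in just one place, so no measured step can serve as a guide, and this expectation is a judgement from the structural change alone. A small upward step in this assay is expected, at the edge of the usual scatter, and it is estimated as a number 0.30 log units higher from compound 3 to compound 4 (within the scatter). The expected value for compound 4 is 3, within an estimated range from 2.6 to 3.5.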

Compound 4, distribution coefficient: 3.3
Beside the measured number, compound 4's estimate is 0.30 log units below it; low and high end bracket the measured number.
By their numbers in this assay, from the lowest: compound 3; then compound 4; then compound 2.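

Among the compounds shown here, this is the first measured step in which only one place changes. In this assay, replacing oxan-3-yl with 1-(methoxymethyl)propyl on the amide-type nitrogen gives a number 0.60 log units higher from compound 3 to compound 4 (beyond the scatter). The two groups have the same counts of heavy atoms, carbon, oxygen, hydrogen-bond donors and hydrogen-bond acceptors, and neither carries a net charge, so the counted difference is that the six-membered non-aromatic ring is gone, and this position shows a change beyond the scatter even with those counts held equal. No measurement here accounts for the rise, so the step stands as an observation without an explanation.

This single pair cannot show whether opening the ring would give a similar step with a different group elsewhere on the shared core, or whether the position of the oxygen within the chain matters. The compounds shown also leave open how this position would read with a chain that has an amine or a carboxylic acid in place of the methoxy group, or with a longer chain.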